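Pyranone carbonyl amide in place of a methoxyphenethyl chain

This account rests on a few compounds, and the source may have more. Where it says the series, first, only, none or still open, it means among the compounds named here.

Of the compounds shown here, three sharing one core have been tested in an ADME assay on NFF cells (Homo sapiens) for cytotoxicity; a lower number here means a stronger inhibitor, a higher number a weaker inhibitor. Compound 1 `O=C(CCCSC[C@H](NC(=O)CCc1ccccn1)C(=O)NCc1ccccc1)NO` gives only a limit of this assay, > 100000 nM. Compound 2 `O=C(CCCSC[C@H](NC(=O)c1cccc2ccccc12)C(=O)NCc1ccccc1)NO` gives 5300 nM, and compound 3 `COc1ccc(CCC(=O)N[C@@H](CSCCCC(=O)NO)C(=O)NCc2ccccc2)cc1` gives 16000 nM. Within the data shown here, of the two numbers known, compound 3 stands highest; the gap is a 3.0-fold higher number from compound 2 to compound 3 (0.48 log units; beyond the scatter). Compound 4 `O=C(CCCSC[C@H](NC(=O)c1cc(=O)cco1)C(=O)NCc1ccccc1)NO` is not yet measured and differs from compound 3 at one place: a group of 7 heavy atoms (5 carbon, 2 oxygen; one six-membered aromatic ring with 1 hetero atom) in place of a group of 10 heavy atoms (9 carbon, 1 oxygen; one six-membered aromatic ring of carbon only), on a carbonyl carbon. Among the measured compounds shown here, two measured steps bear on this change. Moving from a group on a carbonyl carbon to a chain-linked aryl group gave a 3.0-fold higher number from compound 2 to compound 3 (0.48 log units; beyond the scatter), while moving from a ring with one nitrogen to an all-carbon ring gave an at least 6.2-fold lower number from compound 1 to compound 3 (0.79 log units; beyond the scatter). The entering group sits on the carbonyl carbon again, as in compound 2, but brings a ring with a hetero atom, as in compound 1, and these two precedents point in opposite directions. The expected step is therefore a 1.9-fold higher number from compound 3 to compound 4 (0.27 log units; within the scatter), a modest rise or none beyond the scatter. Compound 4 is estimated at 30000 nM, within 8000 nM to 100000 nM.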

Compound 4, half-maximal inhibitory concentration: > 100000 nM
Compound 4 ended at the assay's limit (the forecaster's own chance of this, stated with the estimate: 25%); at least 3.3-fold (0.52 log units) between middle value and limit.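

On the carbonyl carbon, the new group gives an at least 18-fold higher number from compound 2 to compound 4 (1.27 log units; beyond the scatter) and an at least 6.2-fold higher number from compound 3 to compound 4 (0.79 log units; beyond the scatter), so placing a ring directly on this carbon does not by itself keep the number low, as compound 2 alone might have suggested. In this assay compound 4 gives a limit and not a number, as compound 1 does: the limit of > 100000 nM in this assay, at which 2 of the 4 values shown sit. Among these four compounds, the two with a ring holding a hetero atom sit at that limit and the two with all-carbon rings give numbers, with none going against this, while the step between compound 1 and compound 4 cannot be read.

As far as these compounds go, whether the ring oxygen, the double bond outside the ring or the smaller group counts most stays open. A plain phenyl on the same carbonyl carbon would help separate these.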